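Replacing 2-fluorophenyl with furan-2-yl in compound 4

The source may hold more compounds than are shown below. What is called first, only, known or untested is meant among the compounds shown, and "the series" means these compounds.

Compound 1 `C=CCOc1cc(OC)c(C(=O)/C=C/c2ccc(C(F)(F)F)cc2)c(OCC=C)c1`: 7200 nM
Compound 2 `C=CCOc1cc(OC)c(C(=O)/C=C/c2ccc(C)cc2)c(OCC=C)c1`: 211000 nM
Compound 3 `C=CCOc1cc(OC)c(C(=O)/C=C/c2ccccc2F)c(OCC=C)c1`: 16300 nM
Compound 4 `C=CCOc1cc(OC)c(C(=O)/C=C/c2ccco2)c(OCC=C)c1`: not yet measured

In an ADME assay on Vero cells (Chlorocebus sabaeus) for cytotoxicity, read by MTT assay (a lower number here means a stronger inhibitor, a higher number a weaker inhibitor), compound 3 gives the second highest of the three numbers, with compound 1 nearest and compound 2 furthest. Compound 4 carries furan-2-yl in place of 2-fluorophenyl on a double-bonded chain carbon bound to a double-bonded chain carbon. Two measured steps change the group at this place, one modest, a 2.3-fold higher number from compound 1 to compound 3 (0.35 log units; beyond the scatter), and one large, a 13-fold lower number from compound 2 to compound 3 (1.11 log units; beyond the scatter). Neither introduces furan-2-yl, so the direction is uncertain, but a modest rise in this assay is expected. The estimated change is a 2.1-fold higher number from compound 3 to compound 4 (0.33 log units; beyond the scatter). The estimate for compound 4 is 35000 nM, with an expected range of 10000 nM to 130000 nM.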

Compound 4, half-maximal inhibitory concentration: 191000 nM
Estimate against measurement, compound 4: 5.5-fold (0.74 log units) below; measured number above the stated range.
By their numbers in this assay, from the lowest: compound 1; then compound 3; then compounds 4 and 2 (each within the scatter of the next).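

In this assay, furan-2-yl at this place separates sharply from two of the phenyl groups (a 12-fold higher number from compound 3 to compound 4 (1.07 log units; beyond the scatter); a 27-fold higher number from compound 1 to compound 4 (1.42 log units; beyond the scatter)), yet it cannot be told apart from 4-methylphenyl (a 1.1-fold lower number from compound 2 to compound 4 (0.04 log units; within the scatter)). A five-membered aromatic ring with one hetero atom thus falls in with compound 2, leaving compound 1 and compound 3 as the two that stand apart. Nothing shown explains this grouping. From the compounds shown here alone, whether a thiophene or pyridine ring would group with compound 4 or with compound 3 remains open.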